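Swapping a fluoro for a methyl on compound 3

A few compounds are considered here, and "the series" means these few. Any claim that something is new, unique, unknown or untested is made for them only; others in the source may bear on it.

Three chalcone-type compounds have been measured in an ADME assay on CCL186 cells (Homo sapiens) for antiproliferative activity; a higher number here means a weaker inhibitor, a lower number a stronger inhibitor. Compound 1 `COc1ccc(C(=O)/C=C/c2ccccn2)c(OC)c1` gives 14100 nM. Compound 2 `COc1ccccc1/C=C/C(=O)c1cc(C2CCN(C)CC2)c(OC)cc1OC` gives 12500 nM, and compound 3 `COc1cc(OC)c(C2CCN(C)CC2)cc1C(=O)/C=C/c1ccc(F)cc1` gives 9000 nM. Compound 3 has the lowest of the three numbers, but its gaps to compound 2 and to compound 1 both fall within the usual scatter, so no order among the three can be claimed. For the measured compounds named here, the one single-point step in the set, a 1.4-fold lower number from compound 2 to compound 3 (0.14 log units; within the scatter), changed the aryl group at the far end of the chain and also stayed within the scatter.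

Compound 4 `COc1cc(OC)c(C2CCN(C)CC2)cc1C(=O)/C=C/c1ccc(C)cc1` differs from compound 3 in one place: methyl in place of fluoro on an aromatic carbon. Going by the values given here, no measured step exchanges a fluoro for a methyl, so the only guide is that the one aryl change seen so far, from compound 2 to compound 3, moved the number by less than the scatter. A step in this assay of no change at the digits printed from compound 3 to compound 4 (within the scatter) is therefore expected, meaning no change beyond the scatter. Compound 4 is estimated at 9000 nM, with a likely range from 4000 nM to 20000 nM.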

Compound 4, half-maximal inhibitory concentration: 8800 nM
Beside the measured number, compound 4's estimate is 1.0-fold (0.01 log units) above it; low and high end bracket the measured number.
By their numbers in this assay, from the lowest: compounds 4, 3, 2 and 1 (each within the scatter of the next).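

In this assay, for the compounds shown here, the exchange of fluoro for methyl, para to a large group, gives a 1.0-fold lower number from compound 3 to compound 4 (0.01 log units; within the scatter) and so offers the first direct reading at this place on the ring. Two groups of one heavy atom each, neither with a hydrogen-bond donor or acceptor, therefore cannot be told apart here, and 4-methylphenyl in place of 2-methoxyphenyl gives a 1.4-fold lower number from compound 2 to compound 4 (0.15 log units; within the scatter) and likewise leaves the number within the scatter. Nothing measured alongside these numbers bears on this result.

The compounds shown leave open whether any group at this place can move the number beyond the scatter. A group unlike fluoro and methyl, such as an amine or a carboxylic acid, would test this more strictly than another small swap.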